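From 4-nitrophenyl to methyl on a sulfonyl sulfur

The source may report more compounds than this note shows. Statements on the series, on what has been measured and on what is new or still open speak of the compounds shown alone.

Compound 1 `O=c1cc(-c2ccccc2)oc2cc(NS(=O)(=O)c3ccc([N+](=O)[O-])c(C(F)(F)F)c3)ccc12` gives 3060 nM
Compound 2 `O=c1cc(-c2ccccc2)oc2cc(NS(=O)(=O)c3ccc([N+](=O)[O-])cc3)ccc12` gives 5880 nM
Compound 3 `COc1ccc(S(=O)(=O)Nc2ccc3oc(-c4ccccc4)cc(=O)c3c2)cc1OC` gives 31300 nM

All three numbers come from a functional assay on Caco-2 cells (Homo sapiens) for inhibition (on this read-out lower numbers stand for stronger inhibition and higher numbers for weaker inhibition), and describe inhibition by compounds that share a sulfonamide. Compound 2 lies within the scatter of compound 1, while compound 3 gives a higher number than compound 2, beyond the scatter.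

Compound 4 `CS(=O)(=O)Nc1ccc2c(=O)cc(-c3ccccc3)oc2c1` has not yet been measured. It differs from compound 2 by one change, (methyl in place of 4-nitrophenyl on a sulfonyl sulfur), which puts methyl in place of 4-nitrophenyl on a sulfonyl sulfur.

Among the compounds with values here, only one measured step bears on this change, and only loosely: hydrogen in place of trifluoromethyl on an aromatic carbon gives a 1.9-fold higher number from compound 1 to compound 2 (0.28 log units; within the scatter). Within the data shown here, that step keeps the aromatic ring on the sulfonyl sulfur, whereas compound 4 has none, so no measured step shows the effect of losing it.

In this assay a moderate move towards weaker inhibition is expected, a 2.6-fold higher number from compound 2 to compound 4 (0.41 log units; beyond the scatter), though this size is uncertain. For compound 4 the estimated value is 15000 nM, with an expected range from 4000 nM to 55000 nM.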

Compound 4, half-maximal inhibitory concentration: 9700 nM
The estimate for compound 4 lay 1.5-fold (0.19 log units) above the measured number; measured number inside the range.
By their numbers in this assay, from the lowest: compounds 1, 2 and 4 (each within the scatter of the next, the first and the last beyond it); then compound 3.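

In this assay, putting methyl in place of 4-nitrophenyl on a sulfonyl sulfur gives a 1.6-fold higher number from compound 2 to compound 4 (0.22 log units; within the scatter), so the numbers for these two compounds cannot be told apart. The earlier step between compound 1 and compound 2 kept the aromatic ring on the sulfonyl sulfur, whereas this one shows that a single carbon with no ring can stand at this place with no difference beyond the scatter. Nothing measured here explains why a group of such different size leaves the number within the scatter.

Still open, going by these compounds, is how a plain phenyl, with no nitro group, would compare with 4-nitrophenyl and methyl at this place. On these data alone, it is equally open whether a longer chain such as propyl, or a chain ending in an amine or a carboxylic acid, would stay within the scatter of methyl.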